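Swapping the chlorophenyl of compound 1 for a fluorophenyl

The source may hold more compounds than are shown below. What is called first, only, known or untested is meant among the compounds shown, and "the series" means these compounds.

Measured compounds:
- compound 1, `COc1cc2ncnc(NNC(=S)NC(=O)c3ccccc3Cl)c2cc1OC`: 9670 nM
- compound 2, `COc1cc2ncnc(NNC(=S)NC(=O)c3ccc(Cl)cc3)c2cc1OC`: 7530 nM
- compound 3, `COc1cc2ncnc(NNC(=S)NC(=O)c3ccccc3OC)c2cc1OC`: 8410 nM

All three share one core and differ only in the aromatic group attached to the carbonyl carbon. In a functional assay on CNE-2 cells (Homo sapiens) for cytotoxicity, read by MTT assay, with a stated time of 72 h (a lower number here means a stronger inhibitor, a higher number a weaker inhibitor), compound 1 gives the highest of the three numbers, but its nearest neighbour, compound 3, and its furthest, compound 2, both sit within the scatter of it, so none of the three can be called stronger or weaker than another.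

Compound 4, `COc1cc2ncnc(NNC(=S)NC(=O)c3ccc(F)cc3)c2cc1OC`, is not yet measured. It differs from compound 1 in one place: 4-fluorophenyl in place of 2-chlorophenyl on a carbonyl carbon. For the measured compounds named here, two measured steps bear on this change. The step of a 1.3-fold lower number from compound 1 to compound 2 (0.11 log units; within the scatter) moves the chlorine from one ring position to another. The step of a 1.1-fold lower number from compound 1 to compound 3 (0.06 log units; within the scatter) exchanges chlorine for another small group. Both stay within the scatter. Going by the values given here, compound 4 combines a move of the ring substituent with an exchange of one halogen for another, and nothing among the measured compounds suggests a larger effect.

Compound 4 is therefore expected to land near compound 1, with a step of a 1.1-fold lower number from compound 1 to compound 4 (0.06 log units; within the scatter) that lies within the scatter. The estimate for compound 4 in this assay is 8500 nM, with a range from 4000 nM to 18000 nM.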

Compound 4, half-maximal inhibitory concentration: 16100 nM
Compound 4: middle estimate off by 1.9-fold (0.28 log units), on the low side, and the stated range covers the measured number.
By their numbers in this assay, from the lowest: compounds 2, 3, 1 and 4 (each within the scatter of the next, the first and the last beyond it).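

In this assay the earlier swaps on the carbonyl carbon all stayed within the scatter, and two of the new steps do as well: the step of a 1.7-fold higher number from compound 1 to compound 4 (0.22 log units; within the scatter) and the step of a 1.9-fold higher number from compound 3 to compound 4 (0.28 log units; within the scatter). For the compounds shown here, the step of a 2.1-fold higher number from compound 2 to compound 4 (0.33 log units; beyond the scatter) is different, as fluoro in place of chloro on an aromatic carbon gives the first change at this position that lies beyond the scatter, so compound 4 is modestly weaker than compound 2. Even so, nothing shown accounts for this modest gap.

The compounds shown carry only chloro, fluoro and methoxy on the phenyl ring, so it remains open whether this position can respond more strongly. An amine or a carboxylic acid on that ring, or a longer chain in its place on the carbonyl carbon, could still move the number much further.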